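The source may report more compounds than this note shows. Statements on the series, on what has been measured and on what is new or still open speak of the compounds shown alone.

Measured compounds:
compound 1 `O=C(Nc1ccc(Cl)cc1CN1C(=O)c2ccccc2C1=O)c1ccccc1[N+](=O)[O-]` gives 5700 nM in an assay on CHO cells for positive allosteric modulation of metabotropic glutamate receptor 5 (Homo sapiens), read by FLIPR; on this read-out higher numbers stand for an effect only at larger amounts of compound and lower numbers for an effect already at smaller amounts;
compound 2 `CCOc1cccc2c1C(=O)N(Cc1cc(Cl)ccc1NC(=O)c1ccccn1)C2=O` gives 280 nM in this assay.

Of these two values, compound 1 has the higher number, and its gap to compound 2 lies beyond the usual scatter. The unmeasured compound 3 `O=C(Nc1ccc(Cl)cc1CN1C(=O)c2ccccc2C1=O)c1cccnn1` differs from compound 1 by one change: pyridazin-3-yl in place of 2-nitrophenyl on a carbonyl carbon. For the measured compounds named here, no measured pair shows this exact step, so its size is open. In this assay compound 3 is expected to give a lower number than compound 1, a step of a 3.8-fold lower number from compound 1 to compound 3 (0.58 log units; beyond the scatter). Compound 3 is estimated at 1500 nM, with a range from 400 nM to 6000 nM.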

Compound 3, half-maximal effective concentration: > 100000 nM
Compound 3 ended at the assay's limit; the forecaster's own chance of this, stated with the estimate: 20%; middle value at least 66-fold (1.82 log units) away from the limit.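

In this assay compound 3 gives > 100000 nM as a limit of the assay, not a number. On the shared core, pyridazin-3-yl in place of 2-nitrophenyl on the carbonyl carbon gives an at least 17-fold higher number from compound 1 to compound 3 (1.24 log units; beyond the scatter) and so shows that this position does not accept every six-membered aromatic ring alike. For the compounds shown here, this is the first step at this position that can be read from a single change.

As far as these compounds go, it remains open whether the nitro group or the carbon-only ring carries the difference. Plain phenyl, 2-aminophenyl or pyridin-2-yl on the core of compound 1 could separate these.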